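The source may hold more compounds than are shown below. What is called first, only, known or untested is meant among the compounds shown, and "the series" means these compounds.

Measured compounds:
compound 1 `Cc1c(Nc2nc(N)c3c(C#N)c(N4CCC[C@H]4C)n(C)c3n2)cnn1C` – 310 nM
compound 2 `Cc1nn(C2COC2)cc1Nc1nc(N)c2c(C#N)c(N3CCC[C@H]3C)n(C)c2n1` – 240 nM
compound 3 `Cc1nn(C2CCOC2)cc1Nc1nc(N)c2c(C#N)c(N3CCC[C@H]3C)n(C)c2n1` – 140 nM; 260 nM (2 entries)

In an assay on HEK293 cells for inhibition of Leucine-rich repeat serine/threonine-protein kinase 2 (Homo sapiens), with a stated time of 48 h (on this read-out lower numbers stand for stronger inhibition and higher numbers for weaker inhibition), compound 1 gives 310 nM. Of the two compounds with a single number, compound 1 has the higher one, but the step of a 1.3-fold lower number from compound 1 to compound 2 (0.11 log units; within the scatter) is within the scatter, so compound 1 and compound 2 are not separated. Going by the values given here, compound 3 has several entries (the several entries of compound 3 in this assay, 140 nM; 260 nM (2 entries)), and these numbers sit in the same region as those of compound 1 and compound 2; no single step is drawn for that pair.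

Compound 4 `Cc1c(Nc2nc(N)c3c(C#N)c(N4CCC[C@H]4C)n(C)c3n2)cnn1CC1(O)COC1` differs from compound 1 by 3-hydroxyoxetan-3-yl in place of hydrogen on a saturated chain carbon bound to an aromatic nitrogen. Among the compounds with values here, the only measured step that bears on a change at this part of the molecule is the one from compound 1 to compound 2, where a different substituent on the same pyrazole nitrogen gave a step within the scatter, a 1.3-fold lower number from compound 1 to compound 2 (0.11 log units; within the scatter). The entries of compound 3 point the same way. On this basis no step beyond the scatter is expected for compound 4 in this assay, in either direction.

Compound 4 is therefore estimated at 250 nM, with a range from 100 nM to 650 nM, which amounts to an expected step of a 1.2-fold lower number from compound 1 to compound 4 (0.09 log units; within the scatter).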

Compound 4, half-maximal inhibitory concentration: 220 nM
Estimate against measurement, compound 4: 1.1-fold (0.06 log units) above; measured number inside the range.
By their numbers in this assay, from the lowest: compounds 4, 2 and 1 (each within the scatter of the next).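

In this assay, 3-hydroxyoxetan-3-yl in place of hydrogen on a saturated chain carbon bound to an aromatic nitrogen gives a 1.4-fold lower number from compound 1 to compound 4 (0.15 log units; within the scatter), so this change does not separate the two compounds. The earlier step replaced one group on the pyrazole nitrogen with another, whereas this one keeps the methyl carbon and extends it to (3-hydroxyoxetan-3-yl)methyl, adding 5 heavy atoms, a four-membered non-aromatic ring and 1 hydrogen-bond donor with no step beyond the scatter. Repeated entries for a single compound in the series show how far numbers in this range can spread, and the step should be read on that scale: the several entries of compound 3 in this assay, 140 nM; 260 nM (2 entries).

Compound 4 carries the hydroxyl and the four-membered ring together, so the compounds shown do not tell the contribution of either part alone. As far as these compounds go, the response at this chain carbon to an amine, a carboxylic acid or a longer chain remains open, as does whether any such group would give a step beyond the scatter in this assay.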